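Hydroxy on the cyclobutyl group of compound 1

The compounds below may be only part of what the source reports. "The series", "measured", "known", "first", "only" and "open" are said of these compounds alone.

Measured in an ADME assay on microsomes from liver (Mus musculus) for metabolic stability, read by LC-MS, using NADPH, with a stated time of 10 min, tested at 10 uM; on this read-out higher numbers stand for a longer-lived compound and lower numbers for a shorter-lived compound:
compound 1 `N#Cc1ccnc(Oc2nn(C3CCC3)c3ncnc(N)c23)c1`: 0.4 h
compound 2 `Nc1ncnc2c1c(Oc1cc(C(F)(F)F)ccn1)nn2[C@H]1CC[C@@H](N)CC1`: 0.917 h
compound 3 `Nc1ncnc2c1c(Oc1cc(Cl)ccn1)nn2C1CCC1`: 0.0617 h

Compound 1 holds the middle place among the three numbers, under compound 2 and over compound 3. Compound 4 `N#Cc1ccnc(Oc2nn([C@H]3C[C@@H](O)C3)c3ncnc(N)c23)c1` keeps the rest of compound 1 and changes only the cyclobutyl group: hydroxy in place of hydrogen on a saturated ring carbon. Within the data shown here, the only measured step, a 6.5-fold lower number from compound 1 to compound 3 (0.81 log units; beyond the scatter), is modest and beyond the scatter, but it is chloro in place of cyano on an aromatic carbon. It shows how far a single change can move this assay in this series, not which way this one will go. Among the measured compounds shown here, no measured step touches the cyclobutyl group. Compound 1 differs at that place and on the aromatic carbon from compound 2, and compound 2 gives 0.917 h, weak support for a rise. The expected step is a 1.6-fold higher number from compound 1 to compound 4 (0.21 log units; within the scatter), a rise too small to stand clear of the scatter. For compound 4 the estimated half-life is 0.65 h, with an expected range of 0.25 h to 1.5 h.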

Compound 4, half-life: > 2.41 h
Compound 4: a limit, no number; the forecaster's own chance of this, stated with the estimate: 3%; middle value at least 3.7-fold (0.56 log units) away from the limit.
By their numbers in this assay, from the lowest: compound 3; then compound 1; then compound 2. At a limit, above all of these: compound 4.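

In this assay, the cyclobutyl group is a place where a single change moves the read-out strongly: hydroxy in place of hydrogen on a saturated ring carbon gives an at least 6.0-fold higher number from compound 1 to compound 4 (0.77 log units; beyond the scatter). Going by these compounds, compound 4 stands as a limit, not a number, so the full size of this step stays unknown: the limit of > 2.41 h in this assay, at which 1 of the 4 values shown sits. Among these compounds, the only earlier single-place step, a 6.5-fold lower number from compound 1 to compound 3 (0.81 log units; beyond the scatter), lay on an aromatic carbon and said nothing about the cyclobutyl group, whereas this step shows that the series can also move upward from compound 1.

On these data alone, whether a fluorine, a methoxy or a carboxylic acid on the same ring carbon would give a step of the same direction remains open. Also open, as far as these compounds go, is whether hydroxy gives a similar rise with chloro in place of the nitrile, as in compound 3.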